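The compounds below may be only part of what the source reports. "The series", "measured", "known", "first", "only" and "open" are said of these compounds alone.

Values measured in a functional assay (blood) for inhibition, with Homo sapiens as the target; a lower number here means a stronger inhibitor, a higher number a weaker inhibitor:

Compound 1 `COCc1cc(-c2ccccc2)c2ccc(OCc3cccc(C4(O)CCOCC4)c3)cc2c1`: 200 nM
Compound 2 `CC(=O)c1cc(-c2ccccc2)c2ccc(OCc3cccc(C4(O)CCOCC4)c3)cc2c1`: 90 nM

Of the two, compound 2 has the lower number at 90 nM and is the stronger inhibitor. The next compound, compound 3 `COC(=O)c1cc(-c2ccccc2)c2ccc(OCc3cccc(C4(O)CCOCC4)c3)cc2c1`, has methoxy in place of methyl on a carbonyl carbon, so acetyl gives way to methoxycarbonyl.

For the measured compounds named here, only one measured step bears on this change: a 2.2-fold lower number from compound 1 to compound 2 (0.35 log units; beyond the scatter). It put acetyl in place of methoxymethyl on an aromatic carbon, and although modest, it lies beyond the scatter. Going by the values given here, no measured step alters the group on the carbonyl carbon itself, so the data give only indirect guidance. A small step is therefore expected in this assay, no larger than that modest one and possibly within the scatter. A slightly higher number seems the likelier direction, though the data do not settle this. The estimate amounts to an expected 1.3-fold higher number from compound 2 to compound 3 (0.12 log units; within the scatter). For compound 3 the expected value is 120 nM, with an estimated range of 50 nM to 290 nM.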

Compound 3, half-maximal inhibitory concentration: 100 nM
Estimate against measurement, compound 3: 1.2-fold (0.08 log units) above; measured number inside the range.
By their numbers in this assay, from the lowest: compounds 2, 3 and 1 (each within the scatter of the next, the first and the last beyond it).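

In this assay, putting methoxy in place of methyl on a carbonyl carbon, a change the earlier pair left untouched, gives a 1.1-fold higher number from compound 2 to compound 3 (0.05 log units; within the scatter), so acetyl and methoxycarbonyl cannot be told apart in this assay. Set against methoxymethyl on the same aromatic carbon, methoxycarbonyl gives a 2.0-fold lower number from compound 1 to compound 3 (0.30 log units; within the scatter) and stays within the scatter, while acetyl gives a 2.2-fold lower number from compound 1 to compound 2 (0.35 log units; beyond the scatter) and lies just beyond it, so the two carbonyl groups differ only in which side of that line their steps from methoxymethyl fall on, and the data do not separate them from each other. Nothing available here accounts for these numbers.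

The compounds shown leave open whether the carbonyl carbon tolerates more than methyl and methoxy, for example an ethoxy group, an amine that would make an amide, or the hydroxyl of a carboxylic acid. They also leave open whether this aromatic carbon needs a carbonyl at all, since a nitrile or a longer ether chain there would test that directly.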